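The source may report more compounds than this note shows. Statements on the series, on what has been measured and on what is new or still open speak of the compounds shown alone.

Compound 1 `CC1(C)Cc2c(OCc3ccccc3)ccc(C(=O)/C=C/c3cn(-c4ccccc4)nc3-c3ccc(Cl)cc3)c2O1`: 8400 nM in a functional assay on PC-3 cells (Homo sapiens) for antiproliferative activity, read by MTT assay, with a stated time of 48 h; on this read-out lower numbers stand for stronger inhibition and higher numbers for weaker inhibition.
Compound 2 `CC1(C)Cc2c(ccc(C(=O)/C=C/c3cn(-c4ccccc4)nc3-c3ccc([N+](=O)[O-])cc3)c2OCc2ccccc2)O1`: 62300 nM in this assay.
Compound 3 `CC1(C)Cc2c(ccc(C(=O)/C=C/c3ccccc3)c2OCc2ccccc2)O1`: in this assay compound 3 reaches only the limit > 100000 nM, which is a limit of the assay and not a number (the limit of > 100000 nM in this assay, at which 1 of the 3 values shown sits).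

Among the two numbers, compound 2 gives the higher one and compound 1 the lower, a gap beyond the scatter. Compound 4 `Cc1ccc(-c2nn(-c3ccccc3)cc2/C=C/C(=O)c2ccc3c(c2OCc2ccccc2)CC(C)(C)O3)cc1` differs from compound 2 by methyl in place of nitro on an aromatic carbon, a methyl in place of nitro on an aromatic carbon. For the measured compounds named here, no step between measured compounds covers this change, so the direction is uncertain; a modest move toward a lower number is expected, as a 2.1-fold lower number from compound 2 to compound 4 (0.32 log units; beyond the scatter), well within the spread set by compound 2 and compound 1. Compound 4 is therefore estimated at 30000 nM, with a range from 8000 nM to 100000 nM.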

Compound 4, half-maximal inhibitory concentration: 24200 nM
Compound 4: the middle estimate sits 1.2-fold (0.09 log units) above what was measured; low and high end bracket the measured number.
By their numbers in this assay, from the lowest: compound 1; then compound 4; then compound 2. At a limit, above all of these: compound 3.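

For the compounds shown here, the exchange of 4-nitrophenyl for 4-methylphenyl gives a 2.6-fold lower number from compound 2 to compound 4 (0.41 log units; beyond the scatter) and is the first comparison here between compounds that differ in one place. It shows that the group on this aromatic carbon, para to a large group, affects the antiproliferative read-out, though only modestly. Nothing measured here gives a reason for this step.

This single step sets no trend for the position. Going by these compounds, whether an amine, a methoxy group or a carboxylic acid there would give a lower or a higher number remains open.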